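The source may report more compounds than this note shows. Statements on the series, on what has been measured and on what is new or still open speak of the compounds shown alone.

Measured so far in an ADME assay on PC-12 cells (Rattus norvegicus) for cytotoxicity, read by MTT assay, with a stated time of 24 h; a lower number here means a stronger inhibitor, a higher number a weaker inhibitor
- compound 1 `Nc1ncccc1/N=C/c1ccnc(NC(=O)C2CC2)c1` gives 152000 nM
- compound 2 `Nc1ncc(-c2ccccc2)cc1/N=C/c1ccnc(NC(=O)C2CC2)c1` gives 83200 nM

Within the data shown here, compound 2 stands within the scatter of compound 1, the only other measured compound. Compound 3 `Nc1ncc(-c2ccncc2)cc1/N=C/c1ccnc(NC(=O)C2CC2)c1` carries pyridin-4-yl in place of phenyl on an aromatic carbon. Among the measured compounds shown here, the one measured step bearing on this site is the arrival of phenyl on compound 2 (a 1.8-fold lower number from compound 1 to compound 2 (0.26 log units; within the scatter)), and no measured step covers the exchange itself. No shift beyond the scatter is therefore expected in this assay. The expected step is small (a 1.1-fold higher number from compound 2 to compound 3 (0.06 log units; within the scatter)). The estimated value for compound 3 is 95000 nM (range 40000 nM to 220000 nM).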

Compound 3, half-maximal inhibitory concentration: 161000 nM
Compound 3: the middle estimate sits 1.7-fold (0.23 log units) below what was measured; low and high end bracket the measured number.
By their numbers in this assay, from the lowest: compounds 2, 1 and 3 (each within the scatter of the next).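

In this assay, pyridin-4-yl in place of phenyl on this aromatic carbon gives a 1.9-fold higher number from compound 2 to compound 3 (0.29 log units; within the scatter) and stays close to the unsubstituted compound, with pyridin-4-yl in place of hydrogen giving a 1.1-fold higher number from compound 1 to compound 3 (0.02 log units; within the scatter) at the same place. Adding a ring nitrogen to the six-membered aromatic substituent therefore produces no shift beyond the scatter here, and neither aromatic substituent separates from hydrogen. Going by these compounds, whether an amine, a carboxylic acid or a longer alkyl chain on this carbon would move the number beyond the scatter remains open. No supporting data bear on these steps.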